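Hydrazone aryl swap on the shared nucleoside core

The source may report more compounds than this note shows. Statements on the series, on what has been measured and on what is new or still open speak of the compounds shown alone.

Compound 1 `COc1ccc(/C=N/Nc2nc(N)c3ncn([C@@H]4O[C@H](CO)[C@@H](O)[C@H]4O)c3n2)cn1` is the reference point of this small set. Among the measured compounds shown here, in an assay on CHO-K1 cells for displacement of a labelled ligand from adenosine receptor A1 (Homo sapiens), read by scintillation counting, with a stated time of 60 min (a lower number here means a stronger inhibitor, a higher number a weaker inhibitor), compound 1 gives 2.6 nM, the only full number available. Compound 2 `COc1cc(/C=N/Nc2nc(N)c3ncn([C@@H]4O[C@H](CO)[C@@H](O)[C@H]4O)c3n2)cc(OC)c1OC` reaches only a limit in this assay, > 10000 nM, which is the limit described by the limit of > 10000 nM in this assay, at which 1 of the 2 values shown sits. For the measured compounds named here, no step between two measured compounds that differ in one place is available, so the size of a single change cannot be read from a neighbouring pair.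

Compound 3 `N#Cc1ccc(/C=N/Nc2nc(N)c3ncn([C@@H]4O[C@H](CO)[C@@H](O)[C@H]4O)c3n2)cc1` is not yet measured. It differs from compound 1 by 4-cyanophenyl in place of 6-methoxypyridin-3-yl on a carbon with a double bond to nitrogen. Both groups are single six-membered aromatic rings of equal heavy-atom count, each carrying at least one hydrogen-bond acceptor. The step from compound 1 to compound 3 in this assay is expected to be a 3.1-fold higher number from compound 1 to compound 3 (0.49 log units; beyond the scatter), a mild loss at most, within or just beyond the usual scatter. Compound 3 is therefore estimated at 8 nM, with a range from 1.5 nM to 60 nM.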

Compound 3, inhibition constant: 4.1 nM
Compound 3: the middle estimate sits 2.0-fold (0.29 log units) above what was measured, and the stated range covers the measured number.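

In this assay, among the compounds shown here, the change on a carbon with a double bond to nitrogen can now be sized for the first time: a 1.6-fold higher number from compound 1 to compound 3 (0.20 log units; within the scatter). At this place, 4-cyanophenyl and 6-methoxypyridin-3-yl therefore cannot be told apart, so neither the ring nitrogen nor the methoxy group of compound 1 is required for a value at this level. Nothing measured here accounts for this step.

Open, going by these compounds, is how far this tolerance extends, for instance to a carboxylic acid or an amine in place of the nitrile, or to a saturated six-membered ring in place of the aromatic one. Compound 2 stands at a limit of the assay, > 10000 nM, and the compounds shown do not tell which part of its aryl group sets it there.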